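Compound 3: nitro in place of chloro

The source may report more compounds than this note shows. Statements on the series, on what has been measured and on what is new or still open speak of the compounds shown alone.

In a functional assay on NALM-6 cells (Homo sapiens) for cytotoxicity, read by luminescence and CellTiter-Glo, with a stated time of 3 days (a lower number here means a stronger inhibitor, a higher number a weaker inhibitor), compound 1 (`N#Cc1ccc(NC(=O)c2cc(Cl)ccc2O)c(Cl)c1`) gives 730 nM and compound 2 (`O=C(Nc1ccc(Cl)cc1Cl)c1cc(F)ccc1O`) gives 1620 nM as the higher of the two numbers. That gap lies beyond the scatter, so compound 2 stands as the weaker inhibitor of the pair. Compound 3 (`O=C(Nc1ccc([N+](=O)[O-])cc1Cl)c1cc(F)ccc1O`) departs from compound 2 at one place: nitro in place of chloro on an aromatic carbon describes nitro in place of chloro on an aromatic carbon. Within the data shown here, no measured pair isolates this change. A moderate fall in this assay is expected, though a step within the scatter remains possible. Among the measured compounds shown here, the only guide is compound 1 at 730 nM and it is a weak one, as compound 1 differs from compound 2 in more than one place. The estimated move is a 2.2-fold lower number from compound 2 to compound 3 (0.33 log units; beyond the scatter) toward the lower number. Compound 3 is expected at 750 nM (estimated range 270 nM to 1900 nM).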

Compound 3, half-maximal inhibitory concentration: 910 nM
Beside the measured number, compound 3's estimate is 1.2-fold (0.08 log units) below it; the measured number falls inside the stated range.
By their numbers in this assay, from the lowest: compounds 1, 3 and 2 (each within the scatter of the next, the first and the last beyond it).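

In this assay, nitro in place of chloro on an aromatic carbon, meta to a chloro group and para to a large group, gives a 1.8-fold lower number from compound 2 to compound 3 (0.25 log units; within the scatter) and so stays within the scatter. This position therefore takes a group of 3 heavy atoms, with 2 hydrogen-bond acceptors, in place of a single chlorine without a step beyond the scatter, which compounds 1 and 2 could not show, as they differ in more than one place. No measurement at hand bears on the reason for this result.

The compounds shown leave open how an amine, a carboxylic acid or a methyl group would read at this position. This single pair also leaves open whether the same change would give a similar step on a different core.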